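Ethyl to Propargyl at the Aryl Nitrogen of the Core

A few compounds are considered here, and "the series" means these few. Any claim that something is new, unique, unknown or untested is made for them only; others in the source may bear on it.

Measured compounds: compound 1 `C=CCN(Cc1ccc2nc(C)[nH]c(=O)c2c1)c1ccc(C(=O)N[C@@H](CCC(=O)O)C(=O)O)cc1F`, 5160 nM; compound 2 `CCN(Cc1ccc2nc(C)[nH]c(=O)c2c1)c1ccc(C(=O)N[C@@H](CCC(=O)O)C(=O)O)cc1F`, 680 nM.

In an assay on isolated protein for inhibition of Thymidylate synthase (Mus musculus) (a higher number here means a weaker inhibitor, a lower number a stronger inhibitor), compound 2 gives the lowest of the two numbers, its nearest neighbour being compound 1 with a 7.6-fold lower number from compound 1 to compound 2 (0.88 log units; beyond the scatter). Compound 3 `C#CCN(Cc1ccc2nc(C)[nH]c(=O)c2c1)c1ccc(C(=O)N[C@@H](CCC(=O)O)C(=O)O)cc1F` differs from compound 2 by ethynyl in place of methyl on a saturated chain carbon bound to a nitrogen on an aromatic ring. For the measured compounds named here, only the step from compound 1 to compound 2 bears on this change, and it concerns a different unsaturated group, so it guides the expectation loosely. A small improvement or none beyond the scatter is expected, a 1.9-fold lower number from compound 2 to compound 3 (0.29 log units; within the scatter). Compound 3 is estimated at 350 nM, between 100 nM and 1500 nM.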

Compound 3, half-maximal inhibitory concentration: 1430 nM
Compound 3: middle estimate off by 4.1-fold (0.61 log units), on the low side, within the range that was stated.
By their numbers in this assay, from the lowest: compound 2; then compound 3; then compound 1.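

In this assay, ethyl to propargyl weakens inhibition, a 2.1-fold higher number from compound 2 to compound 3 (0.32 log units; beyond the scatter), so at this saturated chain carbon bound to a nitrogen on an aromatic ring, ethynyl does not improve on methyl. Ethynyl still does better than vinyl, a 3.6-fold lower number from compound 1 to compound 3 (0.56 log units; beyond the scatter), so the two unsaturated groups are not interchangeable here, and compound 2 keeps the lowest number of the three. Nothing available explains this order. The compounds shown leave open how a saturated propyl chain or a hydroxyethyl chain on this nitrogen would compare with the ethyl of compound 2.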